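This account rests on a few compounds, and the source may have more. Where it says the series, first, only, none or still open, it means among the compounds named here.

Three compounds carrying the shared core of compound 1 `[N-]=[N+]=NCc1ncnc2c1ncn2[C@@H]1O[C@H](CO)[C@@H](O)[C@H]1O` have been measured in a functional assay on MT4 cells (Homo sapiens) for cytotoxicity, with a stated time of 4 days; a lower number here means that less compound is tolerated, a higher number that more compound is tolerated. In this assay compound 1 gives 32000 nM. Within the data shown here, compound 2 `OC[C@H]1O[C@@H](n2cnc3c(Cn4ccc5ccccc54)ncnc32)[C@H](O)[C@@H]1O` gives 45000 nM in this assay, the highest of the two numbers reported; the only compound with a number near it is compound 1, and the difference between them, a 1.4-fold higher number from compound 1 to compound 2 (0.15 log units; within the scatter), stays within the scatter. Compound 3 `CC(=O)N(Cc1ncnc2c1ncn2[C@H]1C[C@H](O)[C@@H](CO)O1)C1CCCCC1` reaches only a limit in this assay, > 100000 nM, so no number is known for it; the situation is summarized by the limit of > 100000 nM in this assay, at which 1 of the 3 values shown sits.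

Compound 4 `OCCSCc1ncnc2c1ncn2[C@@H]1O[C@H](CO)[C@@H](O)[C@H]1O` has not yet been measured in this assay. It differs from compound 2 by (2-hydroxyethyl)sulfanyl in place of 1H-indol-1-yl on a saturated chain carbon bound to an aromatic carbon. Among the measured compounds shown here, the one measured step at that position, the one from compound 1 to compound 2, lay within the scatter, so the change from compound 2 to compound 4 is expected to produce no step beyond the scatter in this assay, a 1.1-fold higher number from compound 2 to compound 4 (0.05 log units; within the scatter). For compound 4 the estimated value in this assay is therefore 50000 nM, with a range from 20000 nM to 120000 nM.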

Compound 4, half-maximal cytotoxic concentration: > 100000 nM
Compound 4: a limit, no number (the forecaster's own chance of this, stated with the estimate: 35%); middle value at least 2.0-fold (0.30 log units) from the limit.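

At this position, on a saturated chain carbon bound to an aromatic carbon, the earlier replacement of azido by 1H-indol-1-yl stayed within the scatter in this assay, whereas (2-hydroxyethyl)sulfanyl gives an at least 2.2-fold higher number from compound 2 to compound 4 (0.34 log units; beyond the scatter) and an at least 3.1-fold higher number from compound 1 to compound 4 (0.49 log units; beyond the scatter). Compound 4 gives > 100000 nM, which is a limit and not a number, so these two steps show only a minimum size. The group at this position can therefore shift the reading beyond the scatter, and the limit is no longer a single case: the limit of > 100000 nM in this assay, at which 2 of the 4 values shown sit.

As far as these compounds go, how far compound 4 lies past its limit stays open. The compounds shown also do not separate the part played by the sulfur from that of the terminal hydroxyl, which an ethylsulfanyl group, a 2-aminoethylsulfanyl group or a longer hydroxyalkylsulfanyl chain at this position could address.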